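Capping the carboxy group of compound 2

This account rests on a few compounds, and the source may have more. Where it says the series, first, only, none or still open, it means among the compounds named here.

Compound 1 `COc1cc(-c2nc3ccccc3s2)ccc1OCC(=O)NNC(O)CN(C)CC(=O)O`, compound 2 `COc1cc(-c2nc3ccccc3s2)ccc1OCC(=O)NNC(=O)CN[C@@H](CCSC)C(=O)O` and compound 3 `COc1cc(-c2nc3ccccc3s2)ccc1OCC(=O)NNC(=O)CNC(=N)NCCC[C@H](N[N+](=O)[O-])C(=O)O` share one core and differ in the chain that carries a carboxy group. In a functional assay on MCF7 cells (Homo sapiens) for inhibition, read by MTT assay, with a stated time of 3 days (on this read-out higher numbers stand for weaker inhibition and lower numbers for stronger inhibition), compound 1 gives 1960 nM and compound 3 gives 1960 nM while compound 2 gives 1950 nM and so stands level with both, all three lying within the usual scatter.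

Compound 4 `CCOC(=O)[C@H](CCSC)NCC(=O)NNC(=O)COc1ccc(-c2nc3ccccc3s2)cc1OC` keeps everything in compound 2 except one place, where ethyl in place of hydrogen on an oxygen next to a carbonyl group turns carboxy into ethoxycarbonyl. Going by the values given here, no measured pair shows what this change does, so the only guide is that quite different chains leave the numbers together, with compound 2 at 1950 nM as the anchor. In this assay a small step is expected, towards a lower number if there is one, and it may well stay inside the scatter. The estimated step of a 1.1-fold lower number from compound 2 to compound 4 (0.06 log units; within the scatter) is therefore modest. For compound 4 the estimated value is 1700 nM (expected range 700 nM to 4000 nM).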

Compound 4, half-maximal inhibitory concentration: 1760 nM
Estimate against measurement, compound 4: 1.0-fold (0.02 log units) below, within the range that was stated.
By their numbers in this assay, from the lowest: compounds 4, 2, 1 and 3 (each within the scatter of the next).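

In this assay, going by these compounds alone, ethyl in place of hydrogen on an oxygen next to a carbonyl group gives a 1.1-fold lower number from compound 2 to compound 4 (0.04 log units; within the scatter) and this is the first pair here that differs in only one place. At this spot on the chain of compound 2, then, the hydrogen of the carboxy group can give way to ethyl and the two compounds still stand level. No measurement at hand explains why the read-out holds across this change.

As far as these compounds go, it remains open whether a larger group on that oxygen, such as butyl or benzyl, or an amide in place of the ethoxycarbonyl group, would also leave the number in the same place. A single pair speaks only for this chain, so the same swap on the carboxy groups of compound 1 and compound 3 remains an open question.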